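Trading methyl for methylsulfanyl on the fused core

This account rests on a few compounds, and the source may have more. Where it says the series, first, only, none or still open, it means among the compounds named here.

Compound 3 `COc1cc(C)nc2n/c(=N/C(=O)c3c(-c4ccc(Cl)cc4Cl)noc3C)sn12` is the strongest of three compounds tested in a functional assay on the whole organism for inhibition, with Chenopodium ficifolium as the target, with a stated time of 72 h, tested at 100 mg/L (a lower number here means less inhibition of growth, a higher number more inhibition of growth at the concentration tested), where compound 3 gives 80.4%. Its nearest neighbour on the numbers is compound 1 `COc1cc(Cl)nc2n/c(=N/C(=O)c3c(-c4ccc(Cl)cc4Cl)noc3C)sn12`, which gives 65.9%; furthest away is compound 2 `COc1cc(C)nc(NC(=S)NC(=O)c2c(-c3ccc(Cl)cc3Cl)noc2C)n1`, which gives 59.8% and carries an open thiourea bridge rather than the fused core shared by the other two. Among the compounds with values here, the one single-point change among the measured compounds is the step of a number 14.5 percentage points higher from compound 1 to compound 3 (beyond the scatter), a modest gain from swapping a halogen for a small carbon group on the same aromatic carbon.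

Compound 4 `COc1cc(SC)nc2n/c(=N/C(=O)c3c(-c4ccc(Cl)cc4Cl)noc3C)sn12` alters that very carbon again: methylsulfanyl in place of methyl on an aromatic carbon. Within the data shown here, no measured pair shows what happens when methyl gives way to methylsulfanyl, so the only guidance is that this aromatic carbon has already tolerated a change without a large swing. The sulfur-bearing group is larger than what it replaces, and with a single measured step to lean on, the expectation is a small movement in this assay, more likely downward than upward, but not clearly beyond the scatter.

Compound 4 is therefore estimated at 74%, within a range of 56% to 90%, which means an expected step of a number 6.4 percentage points lower from compound 3 to compound 4 (within the scatter).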

Compound 4, percent growth inhibition at one concentration: 68.3%
The estimate for compound 4 lay 5.7 percentage points above the measured number; measured number inside the range.
By their numbers in this assay, from the lowest: compounds 2, 1 and 4 (each within the scatter of the next); then compound 3.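

At this aromatic carbon, methylsulfanyl in place of methyl lowers growth inhibition in this assay, with a number 12.1 percentage points lower from compound 3 to compound 4 (beyond the scatter), so this position does not accept every small replacement of its methyl without loss. Set against the chloro group, methylsulfanyl gives a number 2.4 percentage points higher from compound 1 to compound 4 (within the scatter), which means that these two compounds cannot be told apart here and that the gain seen on going from chloro to methyl does not extend to this sulfur-bearing group. Among the three groups placed on this carbon of the shared core, methyl therefore stands alone at the top, but no supporting data explain why it does better than the other two.

On these data alone, three groups are too few to show what this carbon prefers, so it remains open whether an ethyl group, a longer chain or an amine here would match methyl, or exceed it. As far as these compounds go, it also remains open whether methylsulfanyl would cost the same amount on the open thiourea bridge of compound 2, which carries a methyl on the corresponding ring.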